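Removing one methoxy group in this series

This account rests on a few compounds, and the source may have more. Where it says the series, first, only, none or still open, it means among the compounds named here.

Compound 1 `COc1ccc(-c2cc(/C=C/C(=O)c3ccc(N)cc3)[nH]n2)cc1` gives in a functional assay on SR cells (Homo sapiens) for inhibition, read by sulforhodamine B assay, with a stated time of 48 h (on this read-out lower numbers stand for higher toxicity in this test and higher numbers for lower toxicity in this test), a value of 60100 nM. Compound 2 `COc1ccc(-c2cc(/C=C/C(=O)c3ccc(N)cc3)[nH]n2)cc1OC` differs by one methoxy group. In this assay compound 2 reaches only a limit, > 100000 nM. The measured step, an at least 1.6-fold lower number from compound 2 to compound 1 (0.22 log units; that floor lies within the scatter), is the change (hydrogen in place of methoxy on an aromatic carbon). Compound 3 `COc1cc(C(=O)/C=C/c2cc(-c3cc(OC)c(OC)c(OC)c3)n[nH]2)cc(OC)c1OC` has another core; the difference between the two cores is not broken down here. In this assay compound 3 likewise gives only a limit, > 100000 nM, which is the limit of > 100000 nM in this assay, at which 2 of the 3 values shown sit. Compound 4 `COc1ccc(-c2cc(/C=C/C(=O)c3cc(OC)c(OC)c(OC)c3)[nH]n2)cc1OC` arises from compound 3 by hydrogen in place of methoxy on an aromatic carbon. This is the same kind of change as from compound 2 to compound 1, but here the place is also meta to a methoxy group. A step of similar size is expected, a step that the limit leaves unreadable from compound 3 to compound 4, because an at least 1.6-fold lower number from compound 2 to compound 1 (0.22 log units; that floor lies within the scatter) stays within the scatter. For compound 4 the expected value is 150000 nM, between 60000 nM and 400000 nM, with a limit rather than a number the likelier read-out.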

Compound 4, concentration lethal to 50% of the cells: > 100000 nM
Compound 4: only a limit was reported; the forecaster's own chance of this, stated with the estimate: 70%; the middle value lies beyond the limit too.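

No step can be read from compound 3 to compound 4, since both stop at a limit: the limit of > 100000 nM in this assay, at which 3 of the 4 values shown sit.

The compounds shown leave open whether hydrogen in place of methoxy shifts the read-out at all; only compound 1 gives a number.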